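Sulfonamide Out, Difluorophenyl In: Expectation for Compound 3

The compounds below may be only part of what the source reports. "The series", "measured", "known", "first", "only" and "open" are said of these compounds alone.

Compound 1 `O=C1O/C(=C\Cn2cc(-c3ccc(Br)cc3)nn2)C(OCc2ccccc2)=C1OCc1ccccc1` carries a 4-bromophenyl on its five-membered ring and an exocyclic double bond in the core. In a functional assay on HepG2 cells (Homo sapiens) for antiproliferative activity, read by MTT assay, with a stated time of 72 h (on this read-out lower numbers stand for stronger inhibition and higher numbers for weaker inhibition), compound 1 reaches only the limit of the assay, > 100000 nM. Among the compounds with values here, compound 2 `O=C1O[C@H]([C@@H](O)Cn2cc(CNS(=O)(=O)c3ccc(F)cc3)nn2)C(OCc2ccccc2)=C1OCc1ccccc1` is the hydroxy-bearing analogue with a sulfonamide arm; in this assay compound 2 gives 18300 nM, the only numerical value among the two measured compounds. Compound 3 `O=C1O[C@H]([C@@H](O)Cn2cc(-c3cc(F)cc(F)c3)nn2)C(OCc2ccccc2)=C1OCc1ccccc1` keeps the core of compound 2 and differs in one place: 3,5-difluorophenyl in place of (((4-fluorophenyl)sulfonyl)amino)methyl on an aromatic carbon. Within the data shown here, no measured pair shows this exact change, and compound 1, the only other aryl-bearing compound, sits at the limit on a different core. The step from compound 2 to compound 3 in this assay is expected to be small and, if anything, weakening, a 1.4-fold higher number from compound 2 to compound 3 (0.14 log units; within the scatter). Compound 3 is expected to give about 25000 nM, between 6000 nM and 100000 nM, with a real chance of only a limit.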

Compound 3, half-maximal inhibitory concentration: 11600 nM
For compound 3 the middle estimate is 2.2-fold (0.33 log units) above the measured one, within the range that was stated.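

On the shared core, in this assay, 3,5-difluorophenyl in place of (((4-fluorophenyl)sulfonyl)amino)methyl gives a 1.6-fold lower number from compound 2 to compound 3 (0.20 log units; within the scatter). This position, an aromatic carbon of a five-membered aromatic ring with 3 nitrogen, therefore carries either an aryl group attached directly or the sulfonamide arm with no change that can be told from scatter, even though the hydrogen-bond donor and acceptors counted in the leaving group are absent from the entering one. Compound 3 gives a number on this core, so an aryl group at this position does not by itself bring the read-out to the limit: the limit of > 100000 nM in this assay, at which 1 of the 3 values shown sits.

The compounds shown leave open how an amine, a carboxylic acid or a longer chain carrying the aryl group would read at this position. They also leave open how a plain phenyl would compare with 3,5-difluorophenyl.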